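Swapping the sulfonyl aryl group on two related cores

The compounds below may be only part of what the source reports. "The series", "measured", "known", "first", "only" and "open" are said of these compounds alone.

Compound 1 `COc1ccc2ncc(S(=O)(=O)c3ccc(C)cc3)c(N3CCC(C)CC3)c2c1` was tested in an assay on isolated protein for displacement of a labelled ligand from metabotropic glutamate receptor 5 (Homo sapiens), with a stated time of 60 min, tested at 1 uM (a higher number here means more inhibition at the concentration tested (going by the name of the read-out), a lower number less inhibition), where compound 1 gives 90%. Compound 2 `COc1ccc2ncc(S(=O)(=O)c3cc(F)cc(F)c3)c(N3CCC(C)CC3)c2c1` is its counterpart bearing (3,5-difluorophenyl in place of 4-methylphenyl on a sulfonyl sulfur); in this assay compound 2 gives 30%, so the change brought a number 60 percentage points lower from compound 1 to compound 2 (beyond the scatter). Compound 3 `Cc1ccc(S(=O)(=O)c2cnc3cc(F)ccc3c2N2CCC(C)CC2)cc1` shares the sulfonyl aryl group of compound 1 on a different core; the difference between the two cores is not broken down here. In this assay compound 3 gives 88%. Compound 4 `CC1CCN(c2c(S(=O)(=O)c3cc(F)cc(F)c3)cnc3cc(F)ccc23)CC1` is not yet measured; it carries 3,5-difluorophenyl in place of 4-methylphenyl on a sulfonyl sulfur, the same change that turned compound 1 into compound 2. A step of a number 58 percentage points lower from compound 3 to compound 4 (beyond the scatter) is expected, resting on the earlier a number 60 percentage points lower from compound 1 to compound 2 (beyond the scatter). Compound 4 is therefore estimated at 30%, plausibly between 10% and 55%.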

Compound 4, a percentage reported as inhibition, at one concentration (the size of the read-out at that concentration, not a potency): 77%
The estimate for compound 4 lay 47 percentage points below the measured number; measured number outside the range, above it.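

In this assay, 3,5-difluorophenyl in place of 4-methylphenyl on the sulfonyl sulfur also lowered the number on the core of compound 3, with a step of a number 11 percentage points lower from compound 3 to compound 4 (beyond the scatter). The direction of the change carried over from one core to the other, but its size did not: the same change on two cores in this assay, a number 60 percentage points lower (beyond the scatter) from compound 1 to compound 2 and a number 11 percentage points lower (beyond the scatter) from compound 3 to compound 4, 49 percentage points apart, beyond the scatter of two such steps. This shows that the step on one core was a poor guide to the size of the step on the other, but it does not show what in the cores accounts for the gap, and two pairs set no rule for other cores.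

The compounds shown leave open how a plain phenyl or a 4-methoxyphenyl on the sulfonyl sulfur would behave on these two cores. They also leave open whether the gap would persist if a different amine replaced the one shared by all four compounds.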